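The source may hold more compounds than are shown below. What is called first, only, known or untested is meant among the compounds shown, and "the series" means these compounds.

In an assay on isolated protein for inhibition of histone acetyltransferase p300 (Homo sapiens), with a stated time of 60 min (on this read-out lower numbers stand for stronger inhibition and higher numbers for weaker inhibition), compound 1 `O=C(Nc1ccc2[nH]c(=O)[nH]c2c1)[C@H]1CCCN1C(=O)C1(c2cccc(Cl)c2)CCCC1` gives 0.398 nM, compound 2 `COc1ccc(NC(=O)[C@H]2CCCN2C(=O)C2(c3cccc(Cl)c3)CCCC2)cc1` gives 100 nM, and compound 3 `CNC(=O)c1cccc(NC(=O)[C@H]2CCCN2C(=O)C2(c3cccc(Cl)c3)CCCC2)c1` gives 1260 nM. Compound 3 thus stands at the highest number of the three: the steps of a 3200-fold higher number from compound 1 to compound 3 (3.50 log units; beyond the scatter) and a 13-fold higher number from compound 2 to compound 3 (1.10 log units; beyond the scatter) are both beyond the scatter, and a 250-fold higher number from compound 1 to compound 2 (2.40 log units; beyond the scatter) already marks the loss on leaving the group of compound 1.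

Compound 4 `O=C(Nc1ccc2[nH]nnc2c1)[C@H]1CCCN1C(=O)C1(c2cccc(Cl)c2)CCCC1` differs from compound 3 in a group of 9 heavy atoms (6 carbon, 3 nitrogen; one five-membered aromatic ring with 3 hetero atoms, one six-membered aromatic ring of carbon only) in place of a group of 10 heavy atoms (8 carbon, 1 nitrogen, 1 oxygen; one six-membered aromatic ring of carbon only), on an amide-type nitrogen. The step between compound 1 and compound 3 bears on this most directly: replacing a five-membered aromatic ring with two hetero atoms, joined to a six-membered ring, by a six-membered ring alone gave a 3200-fold higher number from compound 1 to compound 3 (3.50 log units; beyond the scatter). Compound 4 brings back a five-membered aromatic ring with hetero atoms, now three of them and without the oxygen of compound 1, so a large drop in this assay toward the number of compound 1 is expected, though a full return is not assumed. For compound 4 the expected step is a 130-fold lower number from compound 3 to compound 4 (2.10 log units; beyond the scatter). The estimate for compound 4 is 10 nM, within 1 nM to 100 nM.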

Compound 4, half-maximal inhibitory concentration in the histone acetyltransferase p300 assay: 20 nM
Beside the measured number, compound 4's estimate is 2.0-fold (0.30 log units) below it; the range from low to high includes it.
By their numbers in the histone acetyltransferase p300 assay, from the lowest: compound 1; then compound 4; then compound 2; then compound 3.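

In the histone acetyltransferase p300 assay compound 4 gives 20 nM, and its group on the amide-type nitrogen recovers part of the loss seen with compound 3, which gives 1260 nM (a 63-fold lower number from compound 3 to compound 4 (1.80 log units; beyond the scatter)), and also improves on the 4-methoxyphenyl group of compound 2 (a 5.0-fold lower number from compound 2 to compound 4 (0.70 log units; beyond the scatter)). A five-membered aromatic ring with hetero atoms therefore recovers part of the loss but not all of it, since in the histone acetyltransferase p300 assay the group of compound 1 remains clearly ahead (a 50-fold higher number from compound 1 to compound 4 (1.70 log units; beyond the scatter)). The large change for compound 3 and compound 4 is not matched in a physicochemical assay for lipophilicity, at pH 7.4 (on this read-out lower numbers stand for lower lipophilicity and higher numbers for higher lipophilicity), where compound 3 gives 5.5 and compound 4 gives 5.2 (a number 0.30 log units lower from compound 3 to compound 4 (within the scatter)), so the two compounds do not separate on that read-out.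

As far as these compounds go, it remains open whether an amine or a carboxylic acid on the six-membered ring of the group of compound 4 would close the remaining gap to compound 1. Nothing given here explains the differences among these groups.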